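Swapping the branched alkyl group on the imine nitrogen

This account rests on a few compounds, and the source may have more. Where it says the series, first, only, none or still open, it means among the compounds named here.

Measured so far:
- compound 1, `C[C@@H](/N=c1\c(O)c(O)\c1=N/c1ccc2[nH]ncc2c1)C(C)(C)C`: 740 nM
- compound 2, `CC(/N=c1\c(O)c(O)\c1=N/c1ccccc1C#N)C(C)(C)C`: > 30000 nM
- compound 3, `CC(C)C(C)/N=c1\c(O)c(O)\c1=N/c1ccc(C#N)cc1`: 1900 nM

Of the compounds shown here, three sharing one core have been tested in a functional assay for inhibition, with Rattus norvegicus as the target; a higher number here means a weaker inhibitor, a lower number a stronger inhibitor. Compound 1 gives 740 nM in this assay. For compound 2 the result in this assay is only a limit of the assay, > 30000 nM, and not a number; this is the limit of > 30000 nM in this assay, at which 1 of the 3 values shown sits. Compound 3 gives 1900 nM in this assay, the higher of the two numbers, and its gap to compound 1 lies beyond the usual scatter.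

Compound 4, `C[C@H](/N=c1\c(O)c(O)\c1=N/c1ccc(C#N)cc1)C1CCCCC1`, has not yet been measured in this assay. It differs from compound 3 in one place: 1-cyclohexylethyl in place of 1,2-dimethylpropyl on a double-bonded nitrogen. Within the data shown here, no step between two measured compounds shows what such a change does here, so the expectation rests on compound 3 alone. A step of a 1.6-fold lower number from compound 3 to compound 4 (0.20 log units; within the scatter) is expected, roughly none beyond the scatter, perhaps a small move to a lower number. Compound 4 is therefore estimated at 1200 nM in this assay, between 400 nM and 4000 nM.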

Compound 4, half-maximal inhibitory concentration: > 30000 nM
Compound 4: no number, only a limit; the forecaster's own chance of this, stated with the estimate: 5%; at least 25-fold (1.39 log units) between middle value and limit.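

Among these compounds, this position on the double-bonded nitrogen does not accept every branched carbon group in this assay: 1-cyclohexylethyl in place of 1,2-dimethylpropyl brings an at least 15-fold higher number from compound 3 to compound 4 (1.19 log units; beyond the scatter), the first step in this set to show what a change at this place can do. Compound 4 gives > 30000 nM, which is a limit of the assay and not a number, so the step has a known minimum but no known full size. With the rest of the molecule unchanged, this one swap is enough to reach the same limit that was already seen once: the limit of > 30000 nM in this assay, at which 2 of the 4 values shown sit.

The compounds shown leave open whether the ring, the larger carbon count or the defined stereocentre of 1-cyclohexylethyl matters most. They also leave open how a smaller isopropyl group, or a chain carrying an amine, would fare on this nitrogen.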